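Working notes: piperidinyl for arylsulfanyl in a sulfonyl series

The source may hold more compounds than are shown below. What is called first, only, known or untested is meant among the compounds shown, and "the series" means these compounds.

Measured in a functional assay for inhibition of sodium/hydrogen exchanger (Oryctolagus cuniculus); a higher number here means a weaker inhibitor, a lower number a stronger inhibitor:
compound 1 `CCC(C)c1cc(C)c(C(=O)N=C(N)N)cc1S(C)(=O)=O`: 8 nM
compound 2 `Cc1cc(SC(C)C)c(S(C)(=O)=O)cc1C(=O)N=C(N)N`: 12 nM
compound 3 `Cc1cc(Sc2ccccc2Cl)c(S(C)(=O)=O)cc1C(=O)N=C(N)N`: 14 nM

Compound 3 sits within the scatter of both others in this assay: a 1.2-fold higher number from compound 2 to compound 3 (0.07 log units; within the scatter) and a 1.8-fold higher number from compound 1 to compound 3 (0.24 log units; within the scatter). The next compound, compound 4 `Cc1cc(N2CCCCC2)c(S(C)(=O)=O)cc1C(=O)N=C(N)N`, differs from compound 3 in one place: piperidin-1-yl in place of (2-chlorophenyl)sulfanyl on an aromatic carbon. Every step measured so far at this aromatic carbon was flat: a 1.5-fold higher number from compound 1 to compound 2 (0.18 log units; within the scatter), a 1.8-fold higher number from compound 1 to compound 3 (0.24 log units; within the scatter) and a 1.2-fold higher number from compound 2 to compound 3 (0.07 log units; within the scatter). No step yet exchanges a sulfur-linked group for a nitrogen-linked ring, so the change is partly uncharted, but the three flat steps give no reason to expect a move beyond the scatter in this assay. Compound 4 is therefore estimated at 14 nM, range 5 nM to 45 nM. The expected step is no change at the digits printed from compound 3 to compound 4 (within the scatter).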

Compound 4, half-maximal inhibitory concentration: 21 nM
Compound 4: the middle estimate sits 1.5-fold (0.18 log units) below what was measured; the measured number falls inside the stated range.
By their numbers in this assay, from the lowest: compounds 1, 2, 3 and 4 (each within the scatter of the next, the first and the last beyond it).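

In this assay a nitrogen-linked ring on this aromatic carbon stays within the scatter of both sulfur-linked groups (a 1.5-fold higher number from compound 3 to compound 4 (0.18 log units; within the scatter); a 1.8-fold higher number from compound 2 to compound 4 (0.24 log units; within the scatter)). Against sec-butyl, the same ring gives the first step at this carbon beyond the scatter, a modest one (a 2.6-fold higher number from compound 1 to compound 4 (0.42 log units; beyond the scatter)). No measured evidence bears on the reason for this step.

Piperidin-1-yl is the only nitrogen-linked group shown here, so an open-chain amine such as dimethylamino or a morpholine ring could behave differently. Going by these compounds, whether a carbon-linked ring such as cyclohexyl would stay level with sec-butyl also remains open.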